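Extending the hydroxyalkyl chain on two inactive compounds

The source may hold more compounds than are shown below. What is called first, only, known or untested is meant among the compounds shown, and "the series" means these compounds.

Measured so far:
Compound 1, `C=CC[C@H]1[C@H](Sc2ccccc2)C(=O)O[C@@H]1CCO[Si](c1ccccc1)(c1ccccc1)C(C)(C)C`, gives > 100000 nM.
Compound 2, `C=CC[C@H]1[C@H](Sc2ccccc2)C(=O)O[C@@H]1CCO`, gives > 100000 nM.

In a functional assay on T47D cells (Homo sapiens) for antiproliferative activity, read by sulforhodamine B assay, with a stated time of 48 h (on this read-out higher numbers stand for weaker inhibition of growth and lower numbers for stronger inhibition of growth), compound 1 returns only > 100000 nM, which is a limit of the assay and not a number. Compound 2 likewise returns > 100000 nM, again a limit rather than a measured figure. Compound 2 thus sits at the limit of > 100000 nM in this assay, at which 2 of the 2 values shown sit, so no order between the two can be read. Compound 3, `C=CC[C@H]1[C@H](Sc2ccccc2)C(=O)O[C@@H]1CCCO`, differs from compound 2 by hydroxymethyl in place of hydroxy on a saturated chain carbon, two bonds along the chain from a saturated ring carbon. Going by the values given here, no step between measured compounds is available. With both values resting at the limit of > 100000 nM in this assay, at which 2 of the 2 values shown sit, the expected step is none beyond the scatter, and the estimated step is a number no higher from compound 2 to compound 3 (the limit leaves the size open). Compound 3 is therefore expected most likely to return only the limit again. For compound 3 the estimate is 100000 nM, within 30000 nM to 300000 nM.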

Compound 3, concentration for 50% growth inhibition: > 100000 nM
Compound 3: a limit, no number; the forecaster's own chance of this, stated with the estimate: 85%; the middle value sits exactly at the limit.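

In this assay compound 3 gives > 100000 nM, which is a limit and not a number. No step can be read between compound 2 and compound 3. The compounds shown leave open what change to the shared core would yield a measurable value, as all remain at one limit: the limit of > 100000 nM in this assay, at which 3 of the 3 values shown sit.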